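Shortening the Side Chain from Neopentyl to Tert-Butyl

A few compounds are considered here, and "the series" means these few. Any claim that something is new, unique, unknown or untested is made for them only; others in the source may bear on it.

The shared core carries a hydroxylated side chain whose end group is varied. Compound 1 `O=C([C@H](O)c1ccccc1)N1CC[C@@H]2C[C@@]21C(=O)NCc1cc(Cl)ccc1-n1cnnn1` bears a phenyl there, and in a functional assay on a cell-free system (plasma, Homo sapiens), with a stated time of 3 min (a lower number here means a stronger inhibitor, a higher number a weaker inhibitor), compound 1 gives 1100 nM. Compound 2 `CC(C)(C)C[C@@H](O)C(=O)N1CC[C@@H]2C[C@@]21C(=O)NCc1cc(Cl)ccc1-n1cnnn1` carries a neopentyl instead, and in this assay compound 2 gives 620 nM; of the two numbers this is the smaller, but the step of a 1.8-fold lower number from compound 1 to compound 2 (0.25 log units; within the scatter) lies within the scatter, so the two compounds cannot be ranked. Compound 3 `CC(C)(C)[C@@H](O)C(=O)N1CC[C@@H]2C[C@@]21C(=O)NCc1cc(Cl)ccc1-n1cnnn1` differs from compound 2 as follows: tert-butyl in place of neopentyl on a saturated chain carbon bound to a carbonyl carbon and an oxygen on a saturated carbon. Within the data shown here, the only measured step, a 1.8-fold lower number from compound 1 to compound 2 (0.25 log units; within the scatter), concerns a different exchange and was itself within the scatter; no measured pair shows what trimming this chain does. The step of a 1.3-fold higher number from compound 2 to compound 3 (0.11 log units; within the scatter) is therefore expected to be small, with no clear direction beyond the scatter. Compound 3 is estimated at 800 nM in this assay, with a range from 300 nM to 2200 nM.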

Compound 3, half-maximal inhibitory concentration: 1500 nM
The estimate for compound 3 lay 1.9-fold (0.27 log units) below the measured number, and the stated range covers the measured number.
By their numbers in this assay, from the lowest: compounds 2, 1 and 3 (each within the scatter of the next, the first and the last beyond it).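

Trimming neopentyl to tert-butyl is the first change at this position whose step lies beyond the scatter in this assay (a 2.4-fold higher number from compound 2 to compound 3 (0.38 log units; beyond the scatter)), so this position does respond to a small change in the chain, though only modestly. Tert-butyl and phenyl, by contrast, cannot be ranked against each other (a 1.4-fold higher number from compound 1 to compound 3 (0.13 log units; within the scatter)), which means that two quite different end groups can give numbers within the scatter of each other. No measurement offered here accounts for the loss on going from neopentyl to tert-butyl.

Whether a longer chain than neopentyl would bring the number lower still remains open, since neopentyl is the longest chain among these compounds. Also open, going by these compounds, is how an amine or a carboxylic acid at the end of the chain would compare.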